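A Bromine on the Furan Ring of Compound 3

The compounds below may be only part of what the source reports. "The series", "measured", "known", "first", "only" and "open" are said of these compounds alone.

Of the compounds shown here, three have been measured in a functional assay on SJ-G2 cells (Homo sapiens) for inhibition, read by MTT assay, with a stated time of 72 h; a higher number here means a weaker inhibitor of growth, a lower number a stronger inhibitor of growth. Compound 1 `N#C/C(=C\c1c(F)c(F)c(F)c(F)c1F)C(=O)c1ccc[nH]1` gives 23000 nM, compound 2 `N#C/C(=C\c1c[nH]c2ccccc12)C(=O)c1c[nH]c2ccccc12` gives 13000 nM, and compound 3 `COc1ccc(CNC(=O)/C(C#N)=C/c2ccco2)cc1` gives 31000 nM, the highest of the three numbers. The number of compound 3 lies within the scatter of that of compound 1, while the number of compound 2 lies lower by more than the scatter. Compound 4 `COc1ccc(CNC(=O)/C(C#N)=C/c2cc(Br)co2)cc1` is not yet measured; it differs from compound 3 by bromo in place of hydrogen on an aromatic carbon, which, cut one bond further out, reads furan-2-yl to 4-bromofuran-2-yl. Within the data shown here, no step between measured compounds is available, so the expectation rests on the small size of this change: the step of a 1.2-fold lower number from compound 3 to compound 4 (0.09 log units; within the scatter) is expected to remain within the scatter. Compound 4 is therefore estimated at 25000 nM, with a range from 10000 nM to 70000 nM.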

Compound 4, concentration for 50% growth inhibition: 23000 nM
Compound 4: the middle estimate sits 1.1-fold (0.04 log units) above what was measured, within the range that was stated.
By their numbers in this assay, from the lowest: compounds 2, 1, 4 and 3 (each within the scatter of the next, the first and the last beyond it).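

Among these compounds, the step of a 1.3-fold lower number from compound 3 to compound 4 (0.13 log units; within the scatter) in this assay is the first that can be read between two measured compounds differing in one place, and it shows that furan-2-yl and 4-bromofuran-2-yl cannot be told apart here. A single bromine on this aromatic carbon, two ring bonds from the ring oxygen, therefore brings no difference beyond the scatter. No measurement at hand bears on why this is so.

From the compounds shown here alone, whether an amine, a carboxylic acid or a longer chain on this carbon would shift the number beyond the scatter remains open. So does whether bromo on another carbon of the furan ring would give the same result.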